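Fluoro for methyl on the benzylamide of compound 2

This account rests on a few compounds, and the source may have more. Where it says the series, first, only, none or still open, it means among the compounds named here.

Measured compounds:
- compound 1, `Cc1ccsc1C(=CCCN(C)C(CC(C)O)C(=O)NCc1ccccc1Cl)c1sccc1C`: 5.95; 5.67 (2 entries)
- compound 2, `Cc1ccc(CNC(=O)C(CC(C)O)N(C)CCC=C(c2sccc2C)c2sccc2C)cc1`: 6.15

Compound 1 `Cc1ccsc1C(=CCCN(C)C(CC(C)O)C(=O)NCc1ccccc1Cl)c1sccc1C` has been run more than once in a physicochemical assay for lipophilicity, read by HPLC; on this read-out lower numbers stand for lower lipophilicity and higher numbers for higher lipophilicity; the entries read 5.95; 5.67 (2 entries), and their spread the several entries of compound 1 in this assay, 5.95; 5.67 (2 entries) gives a feel for how far repeats of one compound can lie apart here. Within the data shown here, compound 2 `Cc1ccc(CNC(=O)C(CC(C)O)N(C)CCC=C(c2sccc2C)c2sccc2C)cc1` gives 6.15 in this assay; that is the only number recorded for it, and one further entry carries no single number.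

Compound 3 `Cc1ccsc1C(=CCCN(C)C(CC(C)O)C(=O)NCc1ccc(F)cc1)c1sccc1C` has not been measured. Relative to compound 2 the change is fluoro in place of methyl on an aromatic carbon. Both compounds keep the same core, the same amide and the same hydroxy-bearing side chain; only the substituent on the benzyl ring changes.

Among the measured compounds shown here, no step between two measured compounds has been recorded, so the expectation rests on the change itself. A modest fall in this assay is expected, of a size that stays near the usual scatter rather than clearly beyond it. For compound 3 the expected value is 5.8, between 5.4 and 6.2, which would be a step of a number 0.35 log units lower from compound 2 to compound 3 (beyond the scatter).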

Compound 3, partition coefficient: 5.51
For compound 3 the middle estimate is 0.29 log units above the measured one; low and high end bracket the measured number.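

The exchange of 4-methylbenzyl for 4-fluorobenzyl gives the series its first step between two compounds that differ in one place, and in this assay it reads a number 0.64 log units lower from compound 2 to compound 3 (beyond the scatter) as the amide substituent changes. This aromatic carbon, para to a large group, is therefore not silent on this read-out: replacing one heavy atom with another, with no ring, hydrogen-bond donor, hydrogen-bond acceptor or net charge entering or leaving, is enough to move the number while the shared core, the amide and the hydroxy-bearing side chain stay fixed. The step rests on one number at each end, yet it is clearly wider than the distance between repeats of a single compound in this series: the several entries of compound 1 in this assay, 5.95; 5.67 (2 entries)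

Whether the fall belongs to fluoro in particular stays open, since the series shown holds no step at this carbon to a trifluoromethyl, a methoxy, a nitrile, an amine or a carboxylic acid. Also open, on these data alone, is whether the same exchange would give a step of similar size at another carbon of the benzyl ring, or on a core carrying a longer chain.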